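Adding a carboxypyridinyl group to a small oxazole ketone

The compounds below may be only part of what the source reports. "The series", "measured", "known", "first", "only" and "open" are said of these compounds alone.

This study concerns three measured compounds and one yet to be measured, all tested in an assay for inhibition of Fatty-acid amide hydrolase 1 (Rattus norvegicus); on this read-out lower numbers stand for stronger inhibition and higher numbers for weaker inhibition. Compound 1 `O=C(O)c1ccc(-c2cnc(C(=O)CCc3ccc(-c4ccccc4)cc3)o2)nc1` gives 14 nM. Compound 2 `O=C(O)c1ccc(-c2cnc(C(=O)CCc3ccc(Oc4ccccc4)cc3)o2)nc1` gives 33 nM. Among the measured compounds shown here, the step of a 2.4-fold higher number from compound 1 to compound 2 (0.37 log units; beyond the scatter) is the only change between two measured compounds that differ in a single place, and it concerns the tail of the molecule, not the change followed here. Compound 3 `O=C(CCc1ccc(COc2ccccc2)cc1)c1ncco1` gives 25 nM, a number that lies within the usual scatter of both compound 1 and compound 2, so no ordering among the three can be claimed.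

Compound 4 `O=C(O)c1ccc(-c2cnc(C(=O)CCc3ccc(COc4ccccc4)cc3)o2)nc1` differs from compound 3 by 5-carboxypyridin-2-yl in place of hydrogen on an aromatic carbon. For the measured compounds named here, no measured pair isolates this change, so nothing directly tells how large a step to expect. What the numbers do show is that compound 1 and compound 2, which both carry the carboxypyridinyl group, and compound 3, which lacks it, all fall within the scatter of one another. On that basis the step of a 1.3-fold lower number from compound 3 to compound 4 (0.10 log units; within the scatter) is expected to be small, with no clear direction beyond the scatter. Compound 4 is therefore estimated at 20 nM, with a likely range from 6 nM to 60 nM.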

Compound 4, inhibition constant: 4.6 nM
Beside the measured number, compound 4's estimate is 4.3-fold (0.64 log units) above it; the whole stated range lies above it.
By their numbers in this assay, from the lowest: compound 4; then compounds 1, 3 and 2 (each within the scatter of the next, the first and the last beyond it).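

Placing 5-carboxypyridin-2-yl on the aromatic carbon next to the ring oxygen gives the first direct reading of this change in this assay: the step of a 5.4-fold lower number from compound 3 to compound 4 (0.74 log units; beyond the scatter) shows that this position accepts the large group and that the number falls beyond the scatter. With that group in place the tail also counts, since phenoxymethyl stands apart from phenoxy in the step of a 7.2-fold lower number from compound 2 to compound 4 (0.86 log units; beyond the scatter) and from phenyl in the step of a 3.0-fold lower number from compound 1 to compound 4 (0.48 log units; beyond the scatter) and gives the lowest number of the three tails. No measurement shown accounts for these differences.

Still open, going by these compounds, is how much of the step belongs to the carboxylic acid and how much to the pyridine ring, which a methyl ester or a plain pyridin-2-yl at this position would help separate. Also open, on these data alone, is how the phenyl and phenoxy tails behave with hydrogen at this position.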